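This account rests on a few compounds, and the source may have more. Where it says the series, first, only, none or still open, it means among the compounds named here.

Measured in a functional assay on HepG2 cells (Homo sapiens) for cytotoxicity, read by MTT assay, with a stated time of 72 h (a higher number here means a weaker inhibitor, a lower number a stronger inhibitor), compound 1 `COc1ccc(/C=N/NC(=O)Nc2cc3c(Nc4ccc(F)c(Cl)c4)ncnc3cc2O[C@H]2CCOC2)c(OC)c1OC` gives 29300 nM and compound 2 `COc1ccc(/C=N/NC(=O)Nc2cc3c(Nc4ccc(F)c(Cl)c4)ncnc3cc2OC)cc1` gives 21300 nM (a pair within the usual scatter of repeated measurements). On these numbers compound 2 therefore stands level with compound 1. Compound 3 `COc1cc2ncnc(Nc3ccc(F)c(Cl)c3)c2cc1NC(=O)N/N=C/c1ccc(OC)c(OC)c1OC` has not been measured yet. It is compound 2 with 2,3,4-trimethoxyphenyl in place of 4-methoxyphenyl on a carbon with a double bond to nitrogen. Compound 1 at 29300 nM carries the same 2,3,4-trimethoxyphenyl on that carbon, and although it also differs from compound 2 elsewhere on the core, the two values still lie within the scatter of each other. In this assay no step beyond the scatter is therefore expected in either direction, and a 1.1-fold higher number from compound 2 to compound 3 (0.05 log units; within the scatter) is the estimated step. For compound 3 the estimated value is 24000 nM with an expected range from 10000 nM to 55000 nM as the likely span.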

Compound 3, half-maximal inhibitory concentration: 31200 nM
For compound 3 the middle estimate is 1.3-fold (0.11 log units) below the measured one; low and high end bracket the measured number.
By their numbers in this assay, from the lowest: compounds 2, 1 and 3 (each within the scatter of the next).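

With the rest of the molecule unchanged, 2,3,4-trimethoxyphenyl in place of 4-methoxyphenyl on a carbon with a double bond to nitrogen gives a direct reading of this exchange in this assay (a 1.5-fold higher number from compound 2 to compound 3 (0.17 log units; within the scatter)), and no effect can be separated from the scatter. Compound 3 also isolates the other place, where methyl in place of oxolan-3-yl on an oxygen on an aromatic ring gives (a 1.1-fold higher number from compound 1 to compound 3 (0.03 log units; within the scatter)), so this exchange likewise shows no separable effect. Nothing available bears on why these values lie so close.

The groups on that carbon are all phenyl rings bearing methoxy groups, and the oxygen carries only methyl or oxolan-3-yl. As far as these compounds go, whether a phenyl ring bearing an amine or a carboxylic acid, or a butyl chain on that oxygen, would give a step beyond the scatter remains open.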